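Selenium for Sulfur on a Scaffold Showing No Toxicity

The source may report more compounds than this note shows. Statements on the series, on what has been measured and on what is new or still open speak of the compounds shown alone.

Measured compounds in a functional assay on HT-29 cells (Homo sapiens) for cytotoxicity, read by MTT assay, with a stated time of 72 h; a lower number here means that less compound is tolerated, a higher number that more compound is tolerated:
compound 1, `C[Se]/C(=N\C(=O)c1cccs1)NC(=O)c1cccs1`, gives > 100000 nM.
compound 2, `CS/C(=N\C(=O)c1cccs1)NC(=O)c1cccs1`, gives > 100000 nM.
compound 3, `CS/C(=N\C(=O)c1cc(-c2ccccc2)nc2ccccc12)NC(=O)c1cc(-c2ccccc2)nc2ccccc12`, gives > 100000 nM.

Each of these three values is a limit of this assay and not a number. Compound 2 to compound 1 carries the change (a group of 2 heavy atoms (1 carbon, 1 selenium; no ring) in place of a group of 2 heavy atoms (1 carbon, 1 sulfur; no ring), on a carbon with a double bond to nitrogen); the resulting step, a step that the two limits leave unreadable from compound 2 to compound 1, cannot be sized, since (the limit of > 100000 nM in this assay, at which 3 of the 3 values shown sit). The difference between the cores of compound 2 and compound 3 is not broken down here.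

Compound 4, `C[Se]/C(=N\C(=O)c1cc(-c2ccccc2)nc2ccccc12)NC(=O)c1cc(-c2ccccc2)nc2ccccc12`, has not yet been measured in this assay. It differs from compound 3 by a group of 2 heavy atoms (1 carbon, 1 selenium; no ring) in place of a group of 2 heavy atoms (1 carbon, 1 sulfur; no ring), on a carbon with a double bond to nitrogen, the same kind of change as from compound 2 to compound 1, with the place lines agreeing word for word. The step is expected to be a step that the limit leaves unreadable from compound 3 to compound 4, resting on the unreadable step that the two limits leave unreadable from compound 2 to compound 1 and on compound 3 giving the limit > 100000 nM. Compound 4 is therefore estimated at 150000 nM, most likely again as a limit.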

Compound 4, concentration lethal to 50% of the cells: 90700 nM
Compound 4: middle estimate off by 1.7-fold (0.22 log units), on the high side; the range from low to high includes it.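

In this assay, as far as these compounds go, the selenium group in place of methylsulfanyl on the core of compound 3 gives an at least 1.1-fold lower number from compound 3 to compound 4 (0.04 log units; that floor lies within the scatter); this is only a floor, so the true size of the step stays unknown. The same change on the core of compound 1 cannot be read, because both of its values are limits of the assay: the limit of > 100000 nM in this assay, at which 3 of the 4 values shown sit. The change therefore cannot be shown to carry from one core to the other, nor to behave differently on the two.

The compounds shown leave open what an amine or a longer chain would give in place of methylsulfanyl. They also leave open whether any such group on the core of compound 1 would give a value within the range of this assay.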